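One Stereocentre Redrawn in Compound 3

The source may hold more compounds than are shown below. What is called first, only, known or untested is meant among the compounds shown, and "the series" means these compounds.

In an ADME assay on the whole organism (strain CD-1) for metabolic stability, with Mus musculus as the target, at a dose of 3 mg/kg by the intravenous route (a higher number here means that the compound lasts longer, a lower number that the compound disappears faster), compound 1 `CN(Cc1ccccc1OCCCCCC(=O)O)C(=O)c1ccc(-c2ccco2)cc1` gives 1.7 h and compound 2 `CN(Cc1ccccc1OCCC[C@@H]1C[C@@H]1C(=O)O)C(=O)c1ccc(-c2ccco2)cc1` gives 2.7 h. For the measured compounds named here, the one measured step, a 1.6-fold higher number from compound 1 to compound 2 (0.20 log units; within the scatter), puts 2-carboxycyclopropyl in place of 2-carboxyethyl and stays within the scatter. Compound 2 therefore stands level with compound 1. Compound 3 `CN(Cc1ccccc1OCCC[C@@H]1C[C@H]1C(=O)O)C(=O)c1ccc(-c2ccco2)cc1` differs from compound 2 in this way: the two compounds have the same atoms and bonds and differ only in configuration as drawn: 1 of 2 stereo elements differ; a stereocentre at a saturated ring carbon is drawn S in compound 2 and R in compound 3. Going by the values given here, no measured pair tests a change of configuration, so no shift beyond the scatter is expected in this assay. The expected step is a 1.1-fold lower number from compound 2 to compound 3 (0.05 log units; within the scatter). For compound 3 the estimated half-life is 2.4 h, with an expected range of 1.2 h to 4.5 h.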

Compound 3, half-life: 3.5 h
The estimate for compound 3 lay 1.5-fold (0.16 log units) below the measured number; low and high end bracket the measured number.
By their numbers in this assay, from the lowest: compounds 1, 2 and 3 (each within the scatter of the next, the first and the last beyond it).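

At this ring carbon, the drawn configuration makes no readable difference in this assay, with a 1.3-fold higher number from compound 2 to compound 3 (0.11 log units; within the scatter). The comparison is a clean one, and it rests on this: the fact that compounds 2 and 3 differ only in the configuration as drawn. For the compounds shown here, compound 3 also gives the first step beyond the scatter, though a modest one, for 2-carboxycyclopropyl in place of 2-carboxyethyl, with a 2.1-fold higher number from compound 1 to compound 3 (0.31 log units; beyond the scatter), whereas compound 2 stays within the scatter of compound 1.

As far as these compounds go, whether an amine or a longer chain at this place would shift the half-life further stays open.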